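Phenoxy for phenylsulfanyl on a shared core

The compounds below may be only part of what the source reports. "The series", "measured", "known", "first", "only" and "open" are said of these compounds alone.

Measured so far:
compound 1, `CCCN(C)c1nc(N)c(C(=O)N=C(N)N)nc1Cl`: 32%
compound 2, `NC(N)=NC(=O)c1nc(Cl)c(Sc2ccccc2)nc1N`: 11%

Going by the values given here, in an assay for inhibition of acid-sensing ion channel 3 (Homo sapiens), read by patch clamp, tested at 1 uM (on this read-out higher numbers stand for more inhibition at the one concentration tested (going by the name of the read-out) and lower numbers for less inhibition), compound 2 stands lowest of the two numbers known, its nearest neighbour being compound 1, and the one measured step, a number 21 percentage points lower from compound 1 to compound 2 (beyond the scatter), lies beyond the scatter. Compound 3, `NC(N)=NC(=O)c1nc(Cl)c(Oc2ccccc2)nc1N`, differs from compound 2 in a single place: phenoxy in place of phenylsulfanyl on an aromatic carbon. No measured step concerns this exchange; the only step shown describes a different change on the same carbon, so it offers no direct guide. Compound 3 is therefore expected to stay close to compound 2, with a step of a number 1 percentage points higher from compound 2 to compound 3 (within the scatter) that is not expected to pass the scatter, giving an estimate of 12% within 0% to 30%.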

Compound 3, a percentage reported as inhibition, at one concentration (the size of the read-out at that concentration, not a potency): 23%
For compound 3 the middle estimate is 11 percentage points below the measured one; low and high end bracket the measured number.
By their numbers in this assay, from the lowest: compound 2; then compounds 3 and 1 (each within the scatter of the next).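

In this assay, phenoxy in place of phenylsulfanyl on this aromatic carbon gives a number 12 percentage points higher from compound 2 to compound 3 (beyond the scatter) and so shows that the read-out responds to the linking atom alone, with the phenyl ring kept. Phenoxy in place of methyl(propyl)amino gives a number 9 percentage points lower from compound 1 to compound 3 (within the scatter) and leaves compound 3 and compound 1 indistinguishable, so an amino group and an aryl ether can serve about equally at this carbon. On these data alone, whether a primary amine or a longer alkoxy chain here would read any differently stays open. No measurement at hand accounts for the gap between the oxygen and sulfur links.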